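The compounds below may be only part of what the source reports. "The series", "measured", "known", "first", "only" and "open" are said of these compounds alone.

Measured in a functional assay on A-431 cells (Homo sapiens) for cytotoxicity, read by MTT assay, with a stated time of 72 h, tested at 30 uM; a lower number here means less inhibition of growth, a higher number more inhibition of growth at the concentration tested:

compound 1 `Cc1cccc(/C(N)=N/NC(=S)N2CCCCC2)n1` gives 65.2%
compound 2 `N/C(=N\NC(=S)N1CCN(c2ccccn2)CC1)c1ccc(F)cn1` gives 62.3%
compound 3 `Cc1cccc(/C(N)=N/NC(=S)N2CCCC2)n1` gives 72.2%

Compound 2 stands lowest of the three numbers in this assay, but its nearest neighbour compound 1 is within the scatter, and so is compound 3, the furthest; the three values cannot be ordered. Going by the values given here, the one measured step, a number 7 percentage points higher from compound 1 to compound 3 (within the scatter), changes the amine on the thiocarbonyl carbon and stays within the scatter.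

Compound 4 `Cc1cccc(/C(N)=N/NC(=S)N2CCN(c3ccccn3)CC2)n1` has not been measured. It differs from compound 2 by 6-methylpyridin-2-yl in place of 5-fluoropyridin-2-yl on a carbon with a double bond to nitrogen. Among the compounds with values here, no measured step pairs these two aryl groups directly; the only step known, a number 7 percentage points higher from compound 1 to compound 3 (within the scatter), concerns the other end of the molecule. Compounds 1 and 3 carry the same 6-methylpyridin-2-yl group that enters here, and both sit within the scatter of compound 2. The expectation for compound 4 is therefore a step of a number 2.7 percentage points higher from compound 2 to compound 4 (within the scatter), that is, no change beyond the scatter. Compound 4 is estimated at 65%, with a range from 50% to 78%.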

Compound 4, percent growth inhibition at one concentration: 57.4%
Compound 4: middle estimate off by 7.6 percentage points, on the high side; the measured number falls inside the stated range.
By their numbers in this assay, from the lowest: compounds 4, 2, 1 and 3 (each within the scatter of the next, the first and the last beyond it).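

Going by these compounds alone, this is the first direct pairing of the two aryl groups on the carbon with a double bond to nitrogen, with the group on the thiocarbonyl carbon held the same. In this assay, 6-methylpyridin-2-yl in place of 5-fluoropyridin-2-yl gives a number 4.9 percentage points lower from compound 2 to compound 4 (within the scatter), so this single change at this position does not separate the two compounds. No measurement is available that could account for the size of this step.

Going by these compounds, whether the same exchange reads alike with piperidin-1-yl or pyrrolidin-1-yl on the thiocarbonyl carbon stays open, as the 5-fluoropyridin-2-yl group appears here with only one partner. Also open, on these data alone, is how this position responds to a plain phenyl ring, or to a pyridin-2-yl ring carrying a carboxylic acid or an amine.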